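Chloro for Trifluoromethyl on the Urea Aryl Ring

The source may hold more compounds than are shown below. What is called first, only, known or untested is meant among the compounds shown, and "the series" means these compounds.

Compounds measured so far:
compound 1, `COc1cc(Cl)cc(-c2nn(-c3cccc(NC(=O)c4ccc(Cl)c(Cl)c4)c3)cc2-c2ccncc2)c1`: 46%
compound 2, `O=C(Nc1cccc(-n2cc(-c3ccncc3)c(-c3cc(O)cc(Cl)c3)n2)c1)Nc1ccc(Cl)c(C(F)(F)F)c1`: 13.8%

In a functional assay on RPMI-8226 cells (Homo sapiens) for inhibition, read by sulforhodamine B assay, with a stated time of 48 h, tested at 10 uM (on this read-out higher numbers stand for a weaker effect at the one concentration tested and lower numbers for a stronger effect), compound 2 gives 13.8%, the lowest of the two numbers shown; compound 1 sits higher by a margin beyond the usual scatter. Compound 3, `O=C(Nc1cccc(-n2cc(-c3ccncc3)c(-c3cc(O)cc(Cl)c3)n2)c1)Nc1ccc(Cl)c(Cl)c1`, has not yet been measured. It differs from compound 2 in one place only: chloro in place of trifluoromethyl on an aromatic carbon. Among the compounds with values here, no step between two measured compounds isolates this change, so the expectation rests on compound 2 alone. The step expected here is a number 6.2 percentage points higher from compound 2 to compound 3 (within the scatter), pointing toward a somewhat weaker effect at the single concentration, though it may well fall within the scatter of repeated measurements. Compound 3 is therefore estimated at 20% in this assay, with a range from 8% to 40%, the actual number to be filled in once measured.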

Compound 3, a percentage reported as activity, at one concentration (the size of the read-out at that concentration, not a potency): -15.3%
Compound 3: middle estimate off by 35.3 percentage points, on the high side; measured number outside the range, below it.
By their numbers in this assay, from the lowest: compound 3; then compound 2; then compound 1.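

In this assay, putting chloro in place of trifluoromethyl on the aromatic carbon ortho to a chloro group gives a number 29.1 percentage points lower from compound 2 to compound 3 (beyond the scatter), so this position of the urea aryl ring responds clearly to the change. One chlorine atom here, in place of the four heavy atoms of trifluoromethyl, gives the stronger effect at the single concentration, and compound 3 reads -15.3%, a value on the negative side of zero. Nothing available accounts for this difference between the two groups.

As far as these compounds go, whether fluoro, methyl or a plain hydrogen on the same carbon would extend the step or reverse it remains open, since one step sets no trend. From the compounds shown here alone, it is also open whether the same exchange would have a similar effect on a compound that differs elsewhere.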